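Chain shortening on the triazole arm of the shared core

A few compounds are considered here, and "the series" means these few. Any claim that something is new, unique, unknown or untested is made for them only; others in the source may bear on it.

Working notes on a small butenolide set. Going by the values given here, in a functional assay on SW-620 cells (Homo sapiens) for antiproliferative activity, read by MTT assay, with a stated time of 72 h (on this read-out lower numbers stand for stronger inhibition and higher numbers for weaker inhibition), compound 1 `Cc1ccc(S(=O)(=O)NCc2cn(C[C@H](O)[C@H]3OC(=O)C(OCc4ccccc4)=C3OCc3ccccc3)nn2)cc1` gives 45800 nM, the only number in hand. Compound 2 `O=C1O/C(=C\Cn2cc(-c3cc(C(F)(F)F)cc(C(F)(F)F)c3)nn2)C(OCc2ccccc2)=C1OCc1ccccc1` is reported in this assay only as a limit, > 100000 nM, which is the limit of > 100000 nM in this assay, at which 1 of the 2 values shown sits. Compound 3 `O=C1O[C@H]([C@@H](O)Cn2cc(CCCCl)nn2)C(OCc2ccccc2)=C1OCc1ccccc1` differs from compound 1 by 2-chloroethyl in place of ((4-methylphenyl)sulfonyl)amino on a saturated chain carbon bound to an aromatic carbon. Among the compounds with values here, no measured step of this kind is available, so for this assay a step from compound 1 to compound 3 of no more than the usual scatter is expected, with the chance of a limit kept in view. Compound 3 is estimated at 50000 nM, range 15000 nM to 150000 nM, a step of a 1.1-fold higher number from compound 1 to compound 3 (0.04 log units; within the scatter).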

Compound 3, half-maximal inhibitory concentration: 68500 nM
For compound 3 the middle estimate is 1.4-fold (0.14 log units) below the measured one, within the range that was stated.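

On the saturated chain carbon bound to an aromatic carbon, 2-chloroethyl in place of ((4-methylphenyl)sulfonyl)amino gives, in this assay, a 1.5-fold higher number from compound 1 to compound 3 (0.17 log units; within the scatter). At this place, then, the aromatic ring and sulfonyl group of the leaving arm are not needed to hold the value of compound 1. Compound 2 stands only as a limit, not a number: the limit of > 100000 nM in this assay, at which 1 of the 3 values shown sits.

From the compounds shown here alone, whether an amine or a carboxylic acid at this place would shift the value beyond the scatter stays open. So does the effect of a longer chain ending in chlorine.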